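Shortening the ether tail of compound 1

The source may report more compounds than this note shows. Statements on the series, on what has been measured and on what is new or still open speak of the compounds shown alone.

Measured so far:
compound 1 `CN(Cc1cc(C(F)(F)F)cc(C(F)(F)F)c1)C(=O)c1c(OCCCC2CCCCC2)c2ccccc2n(C)c1=O` — 14000 nM
compound 2 `COc1cc(CN(C)C(=O)c2c(OCCCC3CCN(C(=O)OC4(C)CC4)CC3)c3cccnc3n(C)c2=O)cc(C(F)(F)F)c1` — 2400 nM

In an ADME assay for inhibition of phosphatidylcholine:ceramide cholinephosphotransferase 1 (Homo sapiens), read by mass spectrometry, with stated times of 60 min and 30 min (on this read-out higher numbers stand for weaker inhibition and lower numbers for stronger inhibition), compound 1 gives 14000 nM, the higher of the two numbers seen so far. Compound 2 differs from compound 1 in several places at once. Among the compounds with values here, compound 2 gives 2400 nM, a gap that lies beyond the usual scatter; no single step links the two, so only the two values themselves can be compared.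

Compound 3 `CC(C)CCOc1c(C(=O)N(C)Cc2cc(C(F)(F)F)cc(C(F)(F)F)c2)c(=O)n(C)c2ccccc12` is not yet measured. It differs from compound 1 in one place: isopropyl in place of cyclohexylmethyl on a saturated chain carbon, two bonds along the chain from an oxygen on an aromatic ring. Within the data shown here, nothing measured so far isolates this change, and compound 2 cannot be read as a guide to it, since its tail and core both differ from compound 1.

The step from compound 1 to compound 3 is expected to be small, a 1.6-fold higher number from compound 1 to compound 3 (0.20 log units; within the scatter), within the scatter or slightly weakening. The estimate for compound 3 in this assay is 22000 nM, with a range from 7000 nM to 70000 nM.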

Compound 3, half-maximal inhibitory concentration: > 100000 nM
Compound 3 gave a limit, no number; the forecaster's own chance of this, stated with the estimate: 20%; middle value at least 4.5-fold (0.65 log units) from the limit.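

In this assay compound 3 stands at > 100000 nM, which is a limit of the assay and not a number. Isopropyl in place of cyclohexylmethyl on a saturated chain carbon, two bonds along the chain from an oxygen on an aromatic ring, gives an at least 7.1-fold higher number from compound 1 to compound 3 (0.85 log units; beyond the scatter), the first single-place comparison in the series and evidence that this position of the ether tail is sensitive to the change. The full size of the step stays unknown because the read-out for compound 3 ends at a limit: the limit of > 100000 nM in this assay, at which 1 of the 3 values shown sits.

This one change removes the ring and also shortens the group, so the two effects cannot be separated here. A phenyl ring or an open hexyl chain in this place would bear on that question, and compound 2 cannot, since it differs from compound 1 in several places.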